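One chloro fewer than compound 2

This account rests on a few compounds, and the source may have more. Where it says the series, first, only, none or still open, it means among the compounds named here.

In a functional assay on KB cells (Homo sapiens) for inhibition (a higher number here means a weaker inhibitor, a lower number a stronger inhibitor), compound 1 (`Nc1nc2cc(Cl)c(Cl)cc2n1Cc1ccccc1`) reads 170000 nM while compound 2 (`Nc1nc2cc(Cl)c(Cl)cc2n1Cc1ccc(Cl)c(Cl)c1`) stands lowest at 35000 nM by a margin beyond the scatter. Compound 3 (`Nc1nc2cc(Cl)c(Cl)cc2n1Cc1cccc(Cl)c1`) departs from compound 2 with hydrogen in place of chloro on an aromatic carbon. Within the data shown here, no measured single-site step exists as a guide, so only the two values bound the expectation. A moderate rise towards a weaker inhibitor is expected, with the estimated change being a 2.0-fold higher number from compound 2 to compound 3 (0.30 log units; within the scatter) in this assay and likely beyond the scatter. Compound 3 is estimated at 70000 nM (range 30000 nM to 170000 nM).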

Compound 3, half-maximal inhibitory concentration: 65000 nM
The estimate for compound 3 lay 1.1-fold (0.03 log units) above the measured number; low and high end bracket the measured number.
By their numbers in this assay, from the lowest: compounds 2 and 3 (each within the scatter of the next); then compound 1.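

In this assay, replacing the chloro para to a large group with hydrogen gives a 1.9-fold higher number from compound 2 to compound 3 (0.27 log units; within the scatter), so that chloro adds no readable change once the other chloro is present. The remaining chloro alone accounts for the readable step, with a 2.6-fold lower number from compound 1 to compound 3 (0.42 log units; beyond the scatter), a split that compounds 1 and 2 could not provide. Nothing measured bears on the reason for this result.

As far as these compounds go, whether the para chloro alone would match the step from the remaining chloro stays open. So does whether a methoxy group, an amine or a carboxylic acid at this place would move the number beyond the scatter.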